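Acetyl for hydrogen on the ring amine: a forecast

The source may report more compounds than this note shows. Statements on the series, on what has been measured and on what is new or still open speak of the compounds shown alone.

Measured so far: compound 1 `Nc1cc(Cl)c2nc[nH]c2n1` and compound 2 `Cc1ccc(S(=O)(=O)/N=c2\cc(Cl)c3ncn4c3n2C[C@H]2O[C@@H]4[C@@H]3OC(C)(C)O[C@@H]32)cc1`. In a functional assay on HEp-2 cells (Homo sapiens) for cytotoxicity (on this read-out higher numbers stand for an effect only at larger amounts of compound and lower numbers for an effect already at smaller amounts), compound 1 gives 0.3 ug/mL. In this assay compound 2 gives only > 22 ug/mL, which is a limit of the assay and not a number (the limit of > 22 ug/mL in this assay, at which 1 of the 2 values shown sits).

Among the measured compounds shown here, compound 1 thus holds the only real number in this assay; the one other value shown is a limit. For the measured compounds named here, no pair of measured compounds differs in a single place, so no measured step is available, and compound 2 cannot be read as a step from compound 1.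

Compound 3 `CC(=O)Nc1cc(Cl)c2nc[nH]c2n1` differs from compound 1 by acetyl in place of hydrogen on a nitrogen on an aromatic ring. Going by the values given here, with no measured step in this assay to lean on, the expectation rests on the structural change alone. The step of a 3.3-fold higher number from compound 1 to compound 3 (0.52 log units; beyond the scatter) is expected to go toward an effect only at larger amounts, somewhat beyond the scatter but not large, with considerable uncertainty. Compound 3 is therefore estimated at 1 ug/mL in this assay, within a range from 0.2 ug/mL to 6 ug/mL.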

Compound 3, concentration for half-maximal effect: > 22 ug/mL
Compound 3: a limit, no number; the forecaster's own chance of this, stated with the estimate: 15%; middle value at least 22-fold (1.34 log units) away from the limit.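

Among the compounds shown here, the change of amino to acetamido gives the first step that can be read in this assay: an at least 73-fold higher number from compound 1 to compound 3 (1.86 log units; beyond the scatter). For compound 3 the value in this assay is > 22 ug/mL, which is a limit of the assay and not a number, so this step gives only a lower bound on the true size of the change. For the compounds shown here, the nitrogen on the aromatic ring thus proves far less tolerant than the structural change alone suggested, since three heavy atoms in place of a hydrogen are enough to reach the limit, and compound 1 remains the only compound with a real number: the limit of > 22 ug/mL in this assay, at which 2 of the 3 values shown sit.

The compounds shown leave open whether the step follows from the carbonyl or from any substitution of this hydrogen, a question that a methyl group on the same nitrogen, with no carbonyl, would address. They also leave open whether a formyl group, smaller than acetyl, would give a number below the limit in this assay, and so how steep the change at this position is.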